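Propyl on the amide nitrogen of compound 1

The compounds below may be only part of what the source reports. "The series", "measured", "known", "first", "only" and "open" are said of these compounds alone.

Compound 1 `CCC1C(=O)N(C)c2cnc(-n3ccc4cc(C(N)=O)ccc43)nc2N1c1ccn(C)n1` is the weakest of the three measured compounds: in a functional assay on A549 cells (Homo sapiens) for antiproliferative activity, read by CCK-8 assay, with a stated time of 72 h (on this read-out higher numbers stand for weaker inhibition of growth and lower numbers for stronger inhibition of growth), compound 1 gives 39500 nM. Compound 2 `CC[C@@H]1C(=O)N(C)c2cnc(Nc3ccc(S(=O)(=O)NCCO)cc3)nc2N1C1CCCC1` gives 563 nM and compound 3 `CC[C@@H]1C(=O)N(C)c2cnc(Nc3ccc(S(=O)(=O)NCCCO)cc3)nc2N1C1CCCC1` gives 437 nM, both built on a differently substituted shared core. Compound 4 `CCCNC(=O)c1ccc2c(ccn2-c2ncc3c(n2)N(c2ccn(C)n2)C(CC)C(=O)N3C)c1` keeps the core of compound 1 and differs only by propyl in place of hydrogen on an amide-type nitrogen. Going by the values given here, the one single-point step measured, a 1.3-fold lower number from compound 2 to compound 3 (0.11 log units; within the scatter), lengthens a chain on a sulfonamide nitrogen in the other sub-series and does not touch an amide; no measured step bears directly on the present change. The expected step is therefore a 1.3-fold lower number from compound 1 to compound 4 (0.12 log units; within the scatter), anchored to compound 1 because of 39500 nM. The estimate for compound 4 is 30000 nM, with a range of 10000 nM to 90000 nM.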

Compound 4, concentration for 50% growth inhibition: "not active" (no number reported)
The entry for compound 4 holds no number, and the estimate cannot be compared.
By their numbers in this assay, from the lowest: compounds 3 and 2 (each within the scatter of the next); then compound 1.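

In this assay, going by these compounds alone, compound 4 is entered as "not active" without a number, and no step from compound 1 to compound 4 can be read. From the compounds shown here alone, how propyl on the amide-type nitrogen shifts growth inhibition stays open, and no supporting data bear on it.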